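Pyrimidin-2-yl in place of 1-phenyl-1H-tetrazol-5-yl

The compounds below may be only part of what the source reports. "The series", "measured", "known", "first", "only" and "open" are said of these compounds alone.

Compound 1 `Cc1ccc(-c2cs/c(=N/NC(=O)CSc3nnnn3-c3ccccc3)n2-c2ccccc2)cc1`: > 500 ug/mL
Compound 2 `O=C(CSc1nnnn1-c1ccccc1)N/N=c1/scc(-c2ccccc2)n1-c1ccccc1`: 417 ug/mL

In an ADME assay on NIH3T3 cells (Mus musculus) for cytotoxicity, read by MTT assay, with a stated time of 24 h (on this read-out higher numbers stand for weaker inhibition and lower numbers for stronger inhibition), compound 1 gives only a limit of the assay, > 500 ug/mL, not a number (the limit of > 500 ug/mL in this assay, at which 1 of the 2 values shown sits). Compound 2 gives 417 ug/mL in this assay, and the step of an at least 1.1-fold lower number from compound 1 to compound 2 (0.07 log units; that floor lies within the scatter) lies within the scatter. Compound 3 `Cc1ccc(-c2cs/c(=N/NC(=O)CSc3ncccn3)n2-c2ccccc2)cc1` differs from compound 1 by pyrimidin-2-yl in place of 1-phenyl-1H-tetrazol-5-yl on a sulfur. Going by the values given here, no measured step touches this sulfur group, so no measured step bears on the change. The expected step of an at least 1.1-fold lower number from compound 1 to compound 3 (0.04 log units; that floor lies within the scatter) is therefore no more than the scatter. Compound 3 is estimated at 450 ug/mL, with a range from 200 ug/mL to 1000 ug/mL.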

Compound 3, half-maximal inhibitory concentration: > 500 ug/mL
Compound 3: only a limit was reported; the forecaster's own chance of this, stated with the estimate: 55%; middle value at least 1.1-fold (0.04 log units) from the limit.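

Compound 3 gives > 500 ug/mL as a limit of the assay and not a number. Compound 1 also stands at a limit, so the step between compound 1 and compound 3 cannot be read: the limit of > 500 ug/mL in this assay, at which 2 of the 3 values shown sit. On these data alone, how far pyrimidin-2-yl in place of 1-phenyl-1H-tetrazol-5-yl shifts this read-out stays open.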